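Ring substituent size and cytotoxicity in one amine series

This account rests on a few compounds, and the source may have more. Where it says the series, first, only, none or still open, it means among the compounds named here.

Measured in an ADME assay on MDCK cells (Canis lupus familiaris) for cytotoxicity, read by microscopy, with a stated time of 48 h; on this read-out lower numbers stand for higher toxicity in this test and higher numbers for lower toxicity in this test:
compound 1 `CCc1ccc(CN[C@@H]2C[C@H]3C[C@@H]([C@H]2C)C3(C)C)s1` gives 1560 nM
compound 2 `C[C@H]1[C@H](NCc2sccc2C2CCCCC2)C[C@H]2C[C@@H]1C2(C)C` gives 1560 nM
compound 3 `C[C@H]1[C@H](NCc2cc(-c3ccsc3)cs2)C[C@H]2C[C@@H]1C2(C)C` gives 25000 nM

Compound 2 stands level with compound 1 at the digits shown; together they hold the lowest of the three numbers, and compound 3 lies at a far higher number, beyond the scatter. Compound 4 `Cc1ccsc1CN[C@@H]1C[C@H]2C[C@@H]([C@H]1C)C2(C)C` differs from compound 2 by methyl in place of cyclohexyl on an aromatic carbon. Among the compounds with values here, no step between measured compounds is available for this change. Since compound 1, carrying an ethyl group on that ring, gives 1560 nM in this assay, the step of a 1.3-fold higher number from compound 2 to compound 4 (0.11 log units; within the scatter) is expected to be none beyond the scatter. Compound 4 is estimated at 2000 nM, with a range from 800 nM to 6000 nM.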

Compound 4, minimum cytotoxic concentration: 10000 nM
Beside the measured number, compound 4's estimate is 5.0-fold (0.70 log units) below it; measured number outside the range, above it.
By their numbers in this assay, from the lowest: compounds 1 and 2 (each within the scatter of the next); then compound 4; then compound 3.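

In this assay, methyl in place of cyclohexyl on this aromatic carbon gives a 6.4-fold higher number from compound 2 to compound 4 (0.81 log units; beyond the scatter), the first step readable at this position. The number at this place therefore responds to the change of group, and the step lies beyond the scatter. Nothing measured here accounts for the step.

Among the compounds shown, only cyclohexyl and methyl sit at this position, so the trend between them remains undefined. An isopropyl group, a phenyl ring or a longer chain there would show whether the number changes gradually or abruptly.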